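The source may hold more compounds than are shown below. What is called first, only, known or untested is meant among the compounds shown, and "the series" means these compounds.

Measured so far in an ADME assay on PC-3 cells (Homo sapiens) for cytotoxicity, read by sulforhodamine B assay, with a stated time of 48 h, tested at 10 uM; a lower number here means less inhibition, a higher number more inhibition at the concentration tested (going by the name of the read-out):

compound 1 `COc1nc2ccc(Br)cc2cc1C(c1ccccc1)n1cc(C2CC2)nn1` gives 22.6%
compound 2 `CCCCc1cn(C(c2ccccc2)c2cc3cc(Br)ccc3nc2OC)nn1` gives 5.54%
compound 3 `COc1nc2ccc(Br)cc2cc1C(c1ccccc1)n1cc(-c2ccc(F)cc2)nn1` gives 16.4%

Compound 3 stands second highest of the three numbers; its gap to compound 1 is within the scatter, while it sits a number 10.9 percentage points higher from compound 2 to compound 3 (beyond the scatter). Compound 4 `COc1nc2ccc(Br)cc2cc1C(c1ccccc1)n1cc(CCO)nn1` differs from compound 3 by 2-hydroxyethyl in place of 4-fluorophenyl on an aromatic carbon. Among the compounds with values here, the steps that bear on this position are a number 17.1 percentage points lower from compound 1 to compound 2 (beyond the scatter), a number 6.2 percentage points lower from compound 1 to compound 3 (within the scatter) and a number 10.9 percentage points higher from compound 2 to compound 3 (beyond the scatter): only the first and last exceed the scatter, and all three compounds stay low in this assay . Within the data shown here, a 2-hydroxyethyl group at this carbon has no measured precedent here. Compound 4 is therefore expected near the existing cluster, with a step of a number 4.4 percentage points lower from compound 3 to compound 4 (within the scatter), that is, no change beyond the scatter. The estimate for compound 4 is 12%, range 0% to 25%.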

Compound 4, a percentage reported as inhibition, at one concentration (the size of the read-out at that concentration, not a potency): 15.5%
Beside the measured number, compound 4's estimate is 3.5 percentage points below it; low and high end bracket the measured number.
By their numbers in this assay, from the lowest: compounds 2, 4, 3 and 1 (each within the scatter of the next, the first and the last beyond it).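

In this assay, the 2-hydroxyethyl group on this carbon of the five-membered aromatic ring does not separate from 4-fluorophenyl, with a number 0.9 percentage points lower from compound 3 to compound 4 (within the scatter), so exchanging the six-membered aromatic ring for a short chain with a hydrogen-bond donor leaves the number within the scatter. Compound 4 also lies within the scatter of the two compounds that differ from each other, with a number 10 percentage points higher from compound 2 to compound 4 (within the scatter) and a number 7.1 percentage points lower from compound 1 to compound 4 (within the scatter). No evidence on hand accounts for these numbers. As far as these compounds go, whether an amine or a carboxylic acid on this carbon would give a step beyond the scatter remains open.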